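This account rests on a few compounds, and the source may have more. Where it says the series, first, only, none or still open, it means among the compounds named here.

Two carbamates on the shared core have been measured so far. Compound 1 `CCCNC(=O)OC[C@H]1OC(n2cnc3c(NC4CCOC4)ncnc32)[C@H](O)[C@@H]1O` gives 235 nM in an assay on DDT1 cells (Cricetulus griseus) for binding affinity to adenosine receptor A1 (Homo sapiens), read by radioligand binding (on this read-out higher numbers stand for weaker inhibition and lower numbers for stronger inhibition), and compound 2 `O=C(NC1CC1)OC[C@H]1OC(n2cnc3c(NC4CCOC4)ncnc32)[C@H](O)[C@@H]1O` gives 209 nM in this assay. The step of a 1.1-fold lower number from compound 1 to compound 2 (0.05 log units; within the scatter) leaves the two within the scatter of each other, so compound 2 stands alongside compound 1 rather than apart from it.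

Compound 3 `O=C(NC1CCC1)OC[C@H]1OC(n2cnc3c(NC4CCOC4)ncnc32)[C@H](O)[C@@H]1O` carries the change (cyclobutyl in place of cyclopropyl on an amide-type nitrogen). Going by the values given here, the only measured step at this position, a 1.1-fold lower number from compound 1 to compound 2 (0.05 log units; within the scatter), swapped propyl for cyclopropyl on the same amide-type nitrogen without moving the number beyond the scatter. A ring one carbon larger on that nitrogen is a smaller change than the one already seen, so no step beyond the scatter is expected in this assay; the step of a 1.0-fold lower number from compound 2 to compound 3 (0.02 log units; within the scatter) is the estimate. Compound 3 is therefore expected to give 200 nM in this assay, within 100 nM to 400 nM.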

Compound 3, inhibition constant: 306 nM
For compound 3 the middle estimate is 1.5-fold (0.18 log units) below the measured one; low and high end bracket the measured number.
By their numbers in this assay, from the lowest: compounds 2, 1 and 3 (each within the scatter of the next).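

Compound 3 adds a second ring size on the amide-type nitrogen, and in this assay cyclobutyl stays within the scatter of cyclopropyl (a 1.5-fold higher number from compound 2 to compound 3 (0.17 log units; within the scatter)) and of the open-chain propyl (a 1.3-fold higher number from compound 1 to compound 3 (0.11 log units; within the scatter)). Across compounds 1, 2 and 3, this position therefore tolerates all three groups shown, with no compound going against that reading and no order among them that the data can support. Nothing available here explains the numbers or ties them to any feature of these groups.

From the compounds shown here alone, whether cyclopentyl, a longer chain such as butyl, or a chain carrying an amine or a carboxylic acid on the same nitrogen would give a step beyond the scatter remains open. The compounds shown also leave open whether this flat result holds on a different core.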